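From imidazolyl to tert-butyl thiazolyl in a cytotoxicity test

This account rests on a few compounds, and the source may have more. Where it says the series, first, only, none or still open, it means among the compounds named here.

In an ADME assay on MT4 cells (Homo sapiens) for cytotoxicity (on this read-out lower numbers stand for higher toxicity in this test and higher numbers for lower toxicity in this test), compound 1 (`COC(=O)N[C@H](C(=O)NN(CCC[C@@](O)(Cc1ccccc1)C(=O)N[C@H]1c2ccccc2C[C@H]1O)Cc1ccc(F)cc1)C(C)(C)C`) gives > 10000 nM, which is a limit and not a number. Compound 2 (`COC(=O)N[C@H](C(=O)NN(CCC[C@@](O)(Cc1ccccc1)C(=O)N[C@H]1c2ccccc2C[C@H]1O)Cc1ccc(N(C)C)cc1)C(C)(C)C`) also gives only a limit, > 10000 nM. Compound 3 (`COC(=O)N[C@H](C(=O)NN(CCC[C@@](O)(Cc1ccccc1)C(=O)N[C@H]1c2ccccc2C[C@H]1O)Cc1ccc(-n2ccnc2)cc1)C(C)(C)C`) likewise stands at a limit, > 10000 nM. All the measured compounds thus share one reading: the limit of > 10000 nM in this assay, at which 3 of the 3 values shown sit. Compound 4 (`COC(=O)N[C@H](C(=O)NN(CCC[C@@](O)(Cc1ccccc1)C(=O)N[C@H]1c2ccccc2C[C@H]1O)Cc1ccc(-c2nc(C(C)(C)C)cs2)cc1)C(C)(C)C`) differs from compound 3 in a single group: 4-(tert-butyl)-1,3-thiazol-2-yl in place of 1H-imidazol-1-yl on an aromatic carbon. The relevant measured steps are a step that the two limits leave unreadable from compound 1 to compound 3 and a step that the two limits leave unreadable from compound 2 to compound 3, so neither offers a size to carry over. The expected outcome is a step that the limit leaves unreadable from compound 3 to compound 4, with no firm direction, and another limit reading is likely. For compound 4 the estimated value is 12000 nM, with an expected range from 5000 nM to 30000 nM.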

Compound 4, half-maximal cytotoxic concentration: > 10000 nM
Compound 4: only a limit was reported (the forecaster's own chance of this, stated with the estimate: 70%); the middle value is on the limit's open side.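

Compound 4 also gives only a limit, so its steps from compound 1, compound 2 and compound 3 cannot be read: the limit of > 10000 nM in this assay, at which 4 of the 4 values shown sit.

The compounds shown leave open whether compound 1, compound 2, compound 3 and compound 4 differ at all in this assay.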